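Taking the chloro off compound 3

The source may hold more compounds than are shown below. What is called first, only, known or untested is meant among the compounds shown, and "the series" means these compounds.

compound 1 `COc1ccccc1C(=O)O[C@@H]1C[C@H](C)CC[C@H]1C(C)C`: 4.57
compound 2 `COc1cccc(C(=O)O[C@@H]2C[C@H](C)CC[C@H]2C(C)C)c1`: 4.57
compound 3 `CC(C)[C@@H]1CC[C@@H](C)C[C@H]1OC(=O)c1cccc(Cl)c1`: 5.34

Compound 3 has the highest number of the three in a physicochemical assay for lipophilicity, measured as octanol-water partition (a higher number here means a more lipophilic compound, a lower number a more polar compound), with compound 1 and compound 2 each lying below it by the same gap. The next compound, compound 4 `CC(C)[C@@H]1CC[C@@H](C)C[C@H]1OC(=O)c1ccccc1`, differs from it as follows: hydrogen in place of chloro on an aromatic carbon, meta to a large group. Among the measured compounds shown here, one measured step bears on this change: a number 0.77 log units higher from compound 2 to compound 3 (beyond the scatter), with chloro in place of methoxy. For the measured compounds named here, no measured step starts from hydrogen, so this is only a guide. On that basis, a modest fall is expected, estimated as a number 0.72 log units lower from compound 3 to compound 4 (beyond the scatter) in this assay. For compound 4 the estimated value is 4.62, with an expected range from 4.3 to 4.95.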

Compound 4, partition coefficient: 4.82
The estimate for compound 4 lay 0.20 log units below the measured number; low and high end bracket the measured number.
By their numbers in this assay, from the lowest: compounds 1, 2 and 4 (each within the scatter of the next); then compound 3.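

Hydrogen in place of chloro, meta to a large group, gives a number 0.52 log units lower from compound 3 to compound 4 (beyond the scatter) in this assay and so sets chloro apart from hydrogen at this position. Hydrogen in place of methoxy gives a number 0.25 log units higher from compound 2 to compound 4 (within the scatter) and also a number 0.25 log units higher from compound 1 to compound 4 (within the scatter) so neither methoxy compound is separated from compound 4. Among these compounds, only the chloro compound stands apart.

From the compounds shown here alone, how an amine or a carboxylic acid at this position would compare with hydrogen remains open. Nothing available explains why these steps differ in size.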